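The compounds below may be only part of what the source reports. "The series", "measured", "known", "first", "only" and "open" are said of these compounds alone.

Working notes on the series. Three compounds have been run in a functional assay on the whole organism with Mus musculus as the target (on this read-out higher numbers stand for an effect only at larger amounts of compound and lower numbers for an effect already at smaller amounts), so far. Compound 1, `NC(=O)/C=C1\CCc2c(F)cc(F)cc21`, gives 69 mg/kg. Compound 2, `Cc1cccc2c1/C(=C/C(N)=O)CC2`, gives 82 mg/kg, and compound 3, `O=C(/C=C1\CCc2c(F)ccc(F)c21)NC1CC1`, gives 59 mg/kg. Compound 1 sits in the middle of the three numbers, and both its neighbours lie within the scatter of repeated measurements, so nothing separates the three on this read-out. Going by the values given here, no single-point step between measured compounds is available to anchor what a change at the amide end of the chain does.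

The next compound, compound 4, `CN(C)C(=O)/C=C1\CCc2c(F)cc(F)cc21`, is compound 1 with one change: dimethylamino in place of amino on a carbonyl carbon. The closest point of reference is compound 3, where the amide carries a cyclopropyl on the nitrogen and the dose of 59 mg/kg is indistinguishable from that of compound 1. Nothing in the data therefore points to a step beyond the scatter in this assay for the move from a primary to a dimethyl amide; a small shift toward a larger dose is possible but would stay inside the usual scatter. On that basis compound 4 is expected to give about 80 mg/kg, with a range of 40 mg/kg to 160 mg/kg, so that the estimated step of a 1.2-fold higher number from compound 1 to compound 4 (0.06 log units; within the scatter) is essentially flat.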

Compound 4, dose for half-maximal effect: 50 mg/kg
Compound 4: the middle estimate sits 1.6-fold (0.20 log units) above what was measured; low and high end bracket the measured number.
By their numbers in this assay, from the lowest: compounds 4, 3, 1 and 2 (each within the scatter of the next).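

This pair gives the series its first step that can be read at a single place, the amide end of the core of compound 1. In this assay, the step is a 1.4-fold lower number from compound 1 to compound 4 (0.14 log units; within the scatter) for dimethylamino in place of amino on a carbonyl carbon, so replacing the amino group, which carries a hydrogen-bond donor, with dimethylamino, which carries none, gives a step that stays within the scatter on this read-out. This holds for this one pair and this one core only, and nothing at hand bears on why the step has this size.

From the compounds shown here alone, compound 2 and compound 3 each differ from compound 4 in more than one place, so they add nothing to the reading of this change, and whether the same swap behaves alike on their cores remains open. Also open, going by these compounds, is whether a larger group on the amide nitrogen, such as diethylamino or a longer chain, or a carboxylic acid in place of the amide, would stay within the scatter in the same way.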